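The compounds below may be only part of what the source reports. "The series", "measured", "known", "first", "only" and "open" are said of these compounds alone.

Compound 1, `Cc1ccccc1-c1nn(-c2ccc(C(F)(F)F)cc2)cc1CNCCN1CCN(C)CC1`: 11000 nM
Compound 2, `CN1CCN(CCNCc2cn(-c3ccc(C(F)(F)F)cc3)nc2-c2ccc(C(F)(F)F)cc2)CC1`: 1500 nM
Compound 3, `CN1CCN(CCNCc2cn(-c3ccc(C(F)(F)F)cc3)nc2-c2ccc(Cl)cc2)CC1`: 3000 nM

In an ADME assay on Huh-7 cells (Homo sapiens) for cytotoxicity (on this read-out higher numbers stand for lower toxicity in this test and lower numbers for higher toxicity in this test), compound 2 stands at the low end of the three numbers. Its nearest neighbour lies within the scatter, a 2.0-fold higher number from compound 2 to compound 3 (0.30 log units; within the scatter), while the gap to the remaining compound is beyond it, a 7.3-fold lower number from compound 1 to compound 2 (0.87 log units; beyond the scatter). Compound 4, `CN1CCN(CCNCc2cn(-c3ccc([N+](=O)[O-])cc3)nc2-c2ccc(C(F)(F)F)cc2)CC1`, differs from compound 2 in one place: nitro in place of trifluoromethyl on an aromatic carbon. Among the compounds with values here, no measured step touches this position, since the ring that varies among compounds 1 to 3 is the one on the other side of the shared core. The closest measured analogy is a swap of one para substituent for another on that other ring, a 2.0-fold higher number from compound 2 to compound 3 (0.30 log units; within the scatter), which stayed within the scatter; the larger steps, a 7.3-fold lower number from compound 1 to compound 2 (0.87 log units; beyond the scatter) and a 3.7-fold lower number from compound 1 to compound 3 (0.56 log units; beyond the scatter), involved a change of substitution pattern rather than a like-for-like para swap. The expected step from compound 2 to compound 4 is therefore small, a 1.3-fold higher number from compound 2 to compound 4 (0.12 log units; within the scatter), with no clear direction. Compound 4 is estimated at 2000 nM, expected between 800 nM and 5000 nM.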

Compound 4, half-maximal cytotoxic concentration: 3200 nM
Compound 4: the middle estimate sits 1.6-fold (0.20 log units) below what was measured; the measured number falls inside the stated range.
By their numbers in this assay, from the lowest: compounds 2, 3 and 4 (each within the scatter of the next, the first and the last beyond it); then compound 1.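

With nitro in place of trifluoromethyl, this assay gives a 2.1-fold higher number from compound 2 to compound 4 (0.33 log units; beyond the scatter) and so shows that this position on the 4-(trifluoromethyl)phenyl ring can shift the number, if only modestly. The earlier compounds shown here varied only the ring on the other side of the shared core, so they gave no reading of this position, and this single swap shows one direction rather than a trend. No measurement of any property accompanies the step, so the data offer no explanation for it.

Going by these compounds, whether an amine, a carboxylic acid or a nitrile at this position would move the number the same way remains open. Also open, on these data alone, is whether nitro would give a similar step with the 4-chlorophenyl group of compound 3 on the other side.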